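A Nitrile Replaces Two Fluorines on the Benzamide

The source may hold more compounds than are shown below. What is called first, only, known or untested is meant among the compounds shown, and "the series" means these compounds.

Compound 1 `O=C(Nc1cccc(-c2oc3cc(-c4ccc(F)cc4)ccc3c(=O)c2O)c1)c1ccc(Cl)nc1` and compound 2 `O=C(Nc1cccc(-c2oc3cc(-c4ccc(F)cc4)ccc3c(=O)c2O)c1)c1cc(F)cc(F)c1` share one core and differ only in the aromatic group on the carbonyl carbon. In a functional assay on MDA-MB-231 cells (Homo sapiens) for antiproliferative activity, read by CCK-8 assay, with a stated time of 72 h (on this read-out lower numbers stand for stronger inhibition and higher numbers for weaker inhibition), compound 1 gives 1760 nM, and in this assay compound 2 gives 2440 nM. Of the two numbers shown, the one for compound 2 is the higher, yet the step of a 1.4-fold higher number from compound 1 to compound 2 (0.14 log units; within the scatter) lies within the scatter, so the two compounds cannot be told apart on these data. Compound 3 `N#Cc1ccc(C(=O)Nc2cccc(-c3oc4cc(-c5ccc(F)cc5)ccc4c(=O)c3O)c2)cc1` has not yet been measured. It differs from compound 2 by 4-cyanophenyl in place of 3,5-difluorophenyl on a carbonyl carbon. Going by the values given here, the only measured step that bears on such an exchange at the carbonyl carbon is a 1.4-fold higher number from compound 1 to compound 2 (0.14 log units; within the scatter), which stayed within the scatter when one aromatic group replaced another at that place. On that basis the change in compound 3 is expected to give a step of a 1.2-fold lower number from compound 2 to compound 3 (0.07 log units; within the scatter), that is, nothing beyond the scatter in this assay. Compound 3 is therefore estimated at 2100 nM in this assay, with a range from 700 nM to 6500 nM.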

Compound 3, half-maximal inhibitory concentration: 11600 nM
Beside the measured number, compound 3's estimate is 5.5-fold (0.74 log units) below it; measured number above the stated range.
By their numbers in this assay, from the lowest: compounds 1 and 2 (each within the scatter of the next); then compound 3.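

In this assay, the aromatic group on the carbonyl carbon proves not to be freely exchangeable: the first exchange, a 1.4-fold higher number from compound 1 to compound 2 (0.14 log units; within the scatter), stayed within the scatter, but 4-cyanophenyl gives a 4.8-fold higher number from compound 2 to compound 3 (0.68 log units; beyond the scatter) and a 6.6-fold higher number from compound 1 to compound 3 (0.82 log units; beyond the scatter), both beyond it. Replacing 3,5-difluorophenyl with 4-cyanophenyl leaves the heavy-atom count of the group unchanged and keeps a six-membered aromatic ring of carbon only, yet adds a triple bond outside aromatic rings and a hydrogen-bond acceptor, so this place responds to a change that is not one of heavy-atom count. No measurement shown here accounts for the higher number.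

The compounds shown leave open whether the nitrile itself goes with this step or whether the substitution pattern on the ring does, as 4-cyanophenyl differs from 3,5-difluorophenyl in both. A plain phenyl, a 4-fluorophenyl or a 4-methoxyphenyl on the same carbonyl carbon could help separate these two readings and show whether any other group gives a number lower than those of compound 1 and compound 2.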